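The source may report more compounds than this note shows. Statements on the series, on what has been measured and on what is new or still open speak of the compounds shown alone.

Measured compounds:
compound 1 `O=[N+]([O-])c1ccc(Sc2cn(-c3ccc4c(c3)B(O)OC4)c3ccccc23)cc1` — > 10 ug/mL
compound 2 `O=C(c1cccc(Cl)c1)c1ccn(-c2ccc3c(c2)B(O)OC3)c1` — > 10 ug/mL

Both values shown in an ADME assay on L929 cells (Mus musculus) for cytotoxicity, read by resazurin assay, with a stated time of 72 h (on this read-out lower numbers stand for stronger inhibition and higher numbers for weaker inhibition), are limits of the assay and not numbers. Compound 1 sits at its limit, > 10 ug/mL. Compound 2 sits at its limit as well, > 10 ug/mL. Where compound 2 stands is therefore known only as a limit, which is also true of the one further value shown: the limit of > 10 ug/mL in this assay, at which 2 of the 2 values shown sit. Within the data shown here, no pair of measured compounds differs in a single place, so no measured step can be drawn from them.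

Compound 3 `CCCC(=O)c1ccn(-c2ccc3c(c2)B(O)OC3)c1` has not yet been measured. It differs from compound 2 by propyl in place of 3-chlorophenyl on a carbonyl carbon. With both shown values at the limit, the measured data give no direction for this change. The step in this assay is expected to be a step that the limit leaves unreadable from compound 2 to compound 3, none beyond the usual scatter. Compound 3 is accordingly expected to give about 15 ug/mL, within 7 ug/mL to 40 ug/mL, and most likely to be reported again only as a limit.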

Compound 3, half-maximal inhibitory concentration: > 10 ug/mL
Compound 3 was reported as a limit; the forecaster's own chance of this, stated with the estimate: 70%; the middle value lies beyond the limit too.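

In this assay, compound 2 and compound 3 are both reported only as limits, so no step can be read for propyl in place of 3-chlorophenyl on a carbonyl carbon: the limit of > 10 ug/mL in this assay, at which 3 of the 3 values shown sit.

The compounds shown leave open what numerical values compound 1, compound 2 and compound 3 would take, and whether this change moves the read-out at all.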